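A Chlorophenyl Exchange on a Chlorothiophene Pyridine Series

The compounds below may be only part of what the source reports. "The series", "measured", "known", "first", "only" and "open" are said of these compounds alone.

Values in a functional assay on K562 cells (Homo sapiens) for cytotoxicity, read by ELISA, with a stated time of 4 days (on this read-out higher numbers stand for weaker inhibition and lower numbers for stronger inhibition), are
compound 1 `Cc1ccsc1-c1cc(-c2ccco2)cc(-c2ccc(Cl)cc2)n1` gives 20700 nM
compound 2 `Cc1ccsc1-c1cc(-c2ccoc2)cc(-c2ccc(Cl)cc2)n1` gives 19600 nM
compound 3 `Cc1ccc(-c2cc(-c3ccoc3)cc(-c3ccc(Cl)s3)n2)o1` gives 12700 nM

Compound 3 (12700 nM) lies within the scatter of compound 1 and compound 2. Compound 4 `Clc1cccc(-c2cc(-c3ccoc3)cc(-c3ccc(Cl)s3)n2)c1` has 3-chlorophenyl in place of 5-methylfuran-2-yl, next to the ring nitrogen (3-chlorophenyl in place of 5-methylfuran-2-yl on an aromatic carbon). Within the data shown here, no measured step makes this exchange. Among the measured compounds shown here, the only measured step, furan-3-yl in place of furan-2-yl (a 1.1-fold lower number from compound 1 to compound 2 (0.02 log units; within the scatter)), lies within the scatter and is a different exchange, so it bears on this one only loosely. In this assay the expected step therefore stays within the scatter (a 1.0-fold higher number from compound 3 to compound 4 (0.01 log units; within the scatter)). For compound 4 the estimate is 13000 nM (expected range 5000 nM to 30000 nM).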

Compound 4, half-maximal inhibitory concentration: 22100 nM
Beside the measured number, compound 4's estimate is 1.7-fold (0.23 log units) below it; measured number inside the range.
By their numbers in this assay, from the lowest: compounds 3, 2, 1 and 4 (each within the scatter of the next).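

In this assay, among these compounds, the group next to the ring nitrogen was exchanged for the first time, and a five-membered aromatic ring with a hydrogen-bond acceptor gave way to a six-membered aromatic ring of carbon only, with none. This larger exchange gives a 1.7-fold higher number from compound 3 to compound 4 (0.24 log units; within the scatter), so in this pair the loss of that acceptor and the entry of chlorine leave the number within the scatter. Nothing available explains this result. Still open, going by these compounds, is whether an amine or a carboxylic acid at this position would move the number beyond the scatter.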